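Removing the last fluoro from compound 3

This account rests on a few compounds, and the source may have more. Where it says the series, first, only, none or still open, it means among the compounds named here.

Values in a functional assay on the whole organism with Mus musculus as the target (a higher number here means that more compound is needed for the effect, a lower number that less compound is needed), for the compounds measured so far

Compound 1 (`CCCn1c(-c2ccc(Cl)cc2)nn(C)c1=S`) gives 12.5 mg/kg
Compound 2 (`Cn1nc(-c2ccc(F)cc2F)n(C)c1=S`) gives 2.37 mg/kg
Compound 3 (`Cn1nc(-c2ccc(F)cc2)n(C)c1=S`) gives 1 mg/kg

Compound 3 stands lowest of the three in this assay and lies beyond the scatter from both of the others. The next compound, compound 4 (`Cn1nc(-c2ccccc2)n(C)c1=S`), departs from it by hydrogen in place of fluoro on an aromatic carbon (hydrogen in place of fluoro on an aromatic carbon, para to a group of 8 heavy atoms). Among the measured compounds shown here, only one measured step is of this kind, a 2.4-fold lower number from compound 2 to compound 3 (0.37 log units; beyond the scatter), and it is modest. That step removed a different fluoro, so it is a loose guide, and the data do not show whether a second removal would act in the same direction. A change of similar modest size is expected in this assay and its direction is uncertain, with a slight lean towards a higher number since compound 3 already holds the lowest value. The estimated change is a 1.5-fold higher number from compound 3 to compound 4 (0.18 log units; within the scatter) on this reasoning. Compound 4 is expected at about 1.5 mg/kg within an estimated range from 0.6 mg/kg to 4 mg/kg in this measure.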

Compound 4, dose for half-maximal effect: 0.13 mg/kg
For compound 4 the middle estimate is 12-fold (1.06 log units) above the measured one, outside the stated range (below it).
By their numbers in this assay, from the lowest: compound 4; then compound 3; then compound 2; then compound 1.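

In this assay, hydrogen in place of fluoro on an aromatic carbon, para to a group of 8 heavy atoms, gives a 7.7-fold lower number from compound 3 to compound 4 (0.89 log units; beyond the scatter) and leaves compound 4 with the lowest number of the four compounds. The fluoro at this position is therefore not needed for the effect, and the compound with no fluoro at all needs the least dose. Together with a 2.4-fold lower number from compound 2 to compound 3 (0.37 log units; beyond the scatter) as the only other step of this kind, both removals of a fluoro go the same way, and the one at this position is the larger by its printed size, but nothing measured here explains the change.

Going by these compounds, whether a methoxy group or an amine at this position would give a lower or a higher number than hydrogen remains open. So does whether the same step would hold with a longer chain in place of the methyl groups on the shared core.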